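The compounds below may be only part of what the source reports. "The series", "measured", "known", "first", "only" and "open" are said of these compounds alone.

Compound 3 `CC[C@H]1OC(=O)[C@H](C)C(=O)[C@H](C)[C@@H](O[C@@H]2O[C@H](C)C[C@H](N(C)C)[C@H]2O)[C@](C)(O)C[C@@H](C)C(=O)[C@H](C)[C@H]2N(C3CN(Cc4c(O)cnc5ncccc45)C3)C(=O)O[C@]12C` stands at the floor of the numbers shown in an ADME assay on microsomes from liver (Homo sapiens) for metabolic stability, tested at 1 uM; on this read-out lower numbers stand for lower hepatic extraction and higher numbers for higher hepatic extraction: compound 3 gives < 0.3, which is a limit of the assay and not a number. Compound 1 `CC[C@H]1OC(=O)[C@H](C)C(=O)[C@H](C)[C@@H](O[C@@H]2O[C@H](C)C[C@H](N(C)C)[C@H]2O)[C@](C)(O)C[C@@H](C)C(=O)[C@H](C)[C@H]2N(C3CN(Cc4c(O)cnc5cccnc45)C3)C(=O)O[C@]12C` sits at the same place; in this assay compound 1 gives < 0.3, again a limit rather than a number. For the measured compounds named here, compound 2 `CC[C@H]1OC(=O)[C@H](C)C(=O)[C@H](C)[C@@H](O[C@@H]2O[C@H](C)C[C@H](N(C)C)[C@H]2O)[C@](C)(O)C[C@@H](C)C(=O)[C@H](C)[C@H]2N(C3CN(Cc4c(OC)cnc5ccccc45)C3)C(=O)O[C@]12C` is the only measured compound with a plain number, giving 0.6 in this assay. Two of the three measured values therefore rest at the limit of < 0.3 in this assay, at which 2 of the 3 values shown sit.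

The structural change from compound 3 to compound 4 `CC[C@H]1OC(=O)[C@H](C)C(=O)[C@H](C)[C@@H](O[C@@H]2O[C@H](C)C[C@H](N(C)C)[C@H]2O)[C@](C)(O)C[C@@H](C)C(=O)[C@H](C)[C@H]2N(C3CN(Cc4ccncc4Br)C3)C(=O)O[C@]12C` is a group of 7 heavy atoms (5 carbon, 1 nitrogen, 1 bromine; one six-membered aromatic ring with 1 hetero atom) in place of a group of 11 heavy atoms (8 carbon, 2 nitrogen, 1 oxygen; 2 six-membered aromatic rings with 1 hetero atom each), on a saturated chain carbon bound to an amine nitrogen in a ring. The measured steps that bear on it all sit at the same place: a number at least 0.30 higher from compound 1 to compound 2 (beyond the scatter), a number at least 0.30 lower from compound 2 to compound 3 (beyond the scatter), and a step that the two limits leave unreadable from compound 1 to compound 3. The two readable steps are at least modest, so an exchange of the group at this position can move hepatic extraction by a sizeable amount in either direction, while the third step cannot be read from two limits.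

The entering group of compound 4 is smaller than any of the three measured groups, so the comparison rests on range rather than on a close analogue. Compound 4 is expected to give 0.5, within 0.3 to 0.7. The expected step is a number at least 0.20 higher from compound 3 to compound 4 (beyond the scatter).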

Compound 4, hepatic extraction ratio: > 0.8
Compound 4 gave a limit, no number; the forecaster's own chance of this, stated with the estimate: 25%; middle value at least 0.30 away from the limit.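

In this assay compound 4 gives > 0.8, which is a limit of the assay and not a number. With 3-bromopyridin-4-yl on the saturated chain carbon bound to an amine nitrogen in a ring, the read-out moves by a number at least 0.50 higher from compound 3 to compound 4 (beyond the scatter) and by a number at least 0.50 higher from compound 1 to compound 4 (beyond the scatter), and even the 3-methoxyquinolin-4-yl compound is passed, with a number at least 0.20 higher from compound 2 to compound 4 (beyond the scatter). The earlier compounds had shown that an exchange here could matter, but not that a single-ring group could carry the series from one end of the range shown to the other, so this one position now spans both limits of the assay: the limit of > 0.8 in this assay, at which 1 of the 4 values shown sits.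

The true size of these steps remains unknown, and the exchange alters the ring count, the bromine and the hydrogen-bond donor count at once, so the compounds shown do not tell which of these goes with the rise. A plain pyridin-4-yl group, or a pyridin-4-yl group carrying an amine instead of the bromine, at this place would be needed to separate these changes.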